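Phenylsulfonyl for acetyl on the amine of compound 2

A few compounds are considered here, and "the series" means these few. Any claim that something is new, unique, unknown or untested is made for them only; others in the source may bear on it.

The shared core of compound 1 `O=C(OC1CCC(CN2CCN(c3cc(=O)c4cc(C(F)(F)F)cc([N+](=O)[O-])c4s3)CC2)CC1)c1ccco1` carries a saturated ring bearing a ((furan-2-yl)carbonyl)oxy group. In an ADME assay on Vero cells (Chlorocebus sabaeus) for cytotoxicity, read by MTT assay, with a stated time of 48 h (a higher number here means a weaker inhibitor, a lower number a stronger inhibitor), compound 1 gives > 64 ug/mL, which is a limit of the assay and not a number. Compound 2 `CC(=O)NC1CCC(CN2CCN(c3cc(=O)c4cc(C(F)(F)F)cc([N+](=O)[O-])c4s3)CC2)CC1` instead carries an acetamido group on that ring carbon. In this assay compound 2 gives > 64 ug/mL, again a limit. Compound 3 `O=C(OC1CCC(CN2CCN(c3cc(=O)c4cc(C(F)(F)F)cc([N+](=O)[O-])c4s3)CC2)CC1)c1ccncc1` carries a ((pyridin-4-yl)carbonyl)oxy group. In this assay compound 3 gives > 64 ug/mL, also a limit. All three sit at the limit of > 64 ug/mL in this assay, at which 3 of the 3 values shown sit, so compound 2 stands with the others and no order among them can be read. The steps a step that the two limits leave unreadable from compound 1 to compound 2, a step that the two limits leave unreadable from compound 1 to compound 3 and a step that the two limits leave unreadable from compound 2 to compound 3 are therefore unreadable, and none gives a usable size for the change at hand.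

Compound 4 `O=c1cc(N2CCN(CC3CCC(NS(=O)(=O)c4ccccc4)CC3)CC2)sc2c([N+](=O)[O-])cc(C(F)(F)F)cc12` differs from compound 2 by phenylsulfonyl in place of acetyl on an amine nitrogen. With every measured step unreadable, the step that the limit leaves unreadable from compound 2 to compound 4 is expected to be small or none beyond the scatter. Compound 4 is therefore estimated at 80 ug/mL, between 35 ug/mL and 200 ug/mL, and most likely the assay again reports only a limit.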

Compound 4, half-maximal inhibitory concentration: > 64 ug/mL
Compound 4 ended at the assay's limit; the forecaster's own chance of this, stated with the estimate: 80%; the middle value is on the limit's open side.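

Compound 4, like compound 1, compound 2 and compound 3, gives only a limit and not a number, so no step among these compounds can be read: the limit of > 64 ug/mL in this assay, at which 4 of the 4 values shown sit.

The compounds shown leave open how far any of them lies beyond that limit in this assay, and whether the changes on the saturated ring carbon differ in size at all.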